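Ethyl for methyl on the piperazine nitrogen

The compounds below may be only part of what the source reports. "The series", "measured", "known", "first", "only" and "open" are said of these compounds alone.

Measured in an assay for inhibition of tyrosine-protein kinase Mer (Homo sapiens), read by 33P incorporation, in the presence of a further agent that is not named here; a higher number here means a weaker inhibitor, a lower number a stronger inhibitor:
compound 1, `CNc1ncc2c(-c3ccc(N4CCNCC4)nc3)nn(CC3CCCC3)c2n1`, 640 nM
compound 2, `CNc1ncc2c(-c3ccc(N4CCN(C)CC4)nc3)nn(CC3CCCC3)c2n1`, 480 nM

Going by the values given here, compound 2 holds the lower of the two numbers, but the one step so far, a 1.3-fold lower number from compound 1 to compound 2 (0.12 log units; within the scatter), lies within the scatter, so the two compounds cannot be ordered. Compound 3, `CCN1CCN(c2ccc(-c3nn(CC4CCCC4)c4nc(NC)ncc34)cn2)CC1`, differs from compound 2 by methyl in place of hydrogen on a saturated chain carbon bound to an amine nitrogen in a ring. Among the compounds with values here, the only step that bears on this change is a 1.3-fold lower number from compound 1 to compound 2 (0.12 log units; within the scatter), which also altered the group on that amine nitrogen in a ring and moved nothing beyond the scatter. In this assay the step is therefore expected to be a 1.1-fold lower number from compound 2 to compound 3 (0.03 log units; within the scatter). Compound 3 is estimated at 450 nM, in the range 200 nM to 1000 nM.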

Compound 3, half-maximal inhibitory concentration: 2500 nM
Beside the measured number, compound 3's estimate is 5.6-fold (0.74 log units) below it; measured number outside the range, above it.
By their numbers in this assay, from the lowest: compounds 2 and 1 (each within the scatter of the next); then compound 3.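

In this assay 4-ethylpiperazin-1-yl breaks with the flat picture given by hydrogen and methyl on this amine nitrogen: the series shows a 5.2-fold higher number from compound 2 to compound 3 (0.72 log units; beyond the scatter) and a 3.9-fold higher number from compound 1 to compound 3 (0.59 log units; beyond the scatter) as well. At this position, then, one added methyl on the saturated chain carbon moves the number beyond the scatter, which the earlier change on the same nitrogen did not do. No measurement on hand accounts for this step.

From the compounds shown here alone, whether a longer chain such as propyl or a ring such as cyclopropyl on this nitrogen raises the number further stays open. So does whether a hydroxyethyl group behaves like ethyl.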